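Swapping the five-membered ring on a weak HeLa inhibitor

The source may hold more compounds than are shown below. What is called first, only, known or untested is meant among the compounds shown, and "the series" means these compounds.

Of the compounds shown here, two have been tested in a functional assay on HeLa cells (Homo sapiens) for antiproliferative activity, read by MTT assay, with a stated time of 72 h; on this read-out higher numbers stand for weaker inhibition and lower numbers for stronger inhibition. Compound 1 `Cn1cc(-c2nn(Cc3ccc(C(=O)NC4CCCC4)cc3)c(=O)c3ccccc23)cn1` gives 16700 nM in this assay. Compound 2 `Cc1noc(C)c1-c1nn(Cc2ccc(C(=O)NC3CC(C)(C)N([O])C(C)(C)C3)cc2)c(=O)c2ccccc12` gives 83500 nM in this assay, the higher of the two numbers and therefore the weaker inhibitor; its gap to compound 1 is beyond the usual scatter. Going by the values given here, the two compounds differ in two places at once, in the amide substituent and in the five-membered aromatic ring, so no single structural step has been measured here.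

Compound 3 `Cn1cc(-c2nn(Cc3ccc(C(=O)NC4CC(C)(C)N([O])C(C)(C)C4)cc3)c(=O)c3ccccc23)cn1` keeps the amide substituent of compound 2 and changes only the aromatic ring: 1-methyl-1H-pyrazol-4-yl in place of 3,5-dimethyl-1,2-oxazol-4-yl on an aromatic carbon. Compound 1 carries this same 1-methyl-1H-pyrazol-4-yl ring, and its lower number suggests the ring may be the more favourable one, though the amide difference cannot be separated from it. The step from compound 2 to compound 3 in this assay is expected to be a modest move toward stronger inhibition, estimated as a 2.1-fold lower number from compound 2 to compound 3 (0.32 log units; beyond the scatter). Compound 3 is accordingly estimated at 40000 nM in this assay, with a likely range from 12000 nM to 120000 nM.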

Compound 3, half-maximal inhibitory concentration: 27700 nM
Beside the measured number, compound 3's estimate is 1.4-fold (0.16 log units) above it; the measured number falls inside the stated range.
By their numbers in this assay, from the lowest: compounds 1 and 3 (each within the scatter of the next); then compound 2.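

In this assay the ring change now stands alone, and there is a 3.0-fold lower number from compound 2 to compound 3 (0.48 log units; beyond the scatter) when 1-methyl-1H-pyrazol-4-yl replaces 3,5-dimethyl-1,2-oxazol-4-yl on this aromatic carbon, so this position affects the read-out by itself, if only modestly. Going by these compounds alone, the amide substituent can also be read separately for the first time: there is a 1.7-fold higher number from compound 1 to compound 3 (0.22 log units; within the scatter) when the group with a six-membered non-aromatic ring holding a hetero atom replaces the group with a five-membered carbon ring on the amide-type nitrogen, so these two compounds cannot be told apart. Of the two places where compound 1 and compound 2 differ, only the ring change gives a step beyond the usual scatter when read alone.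

Nothing available explains why the pyrazole ring gives the lower number in this pair. Going by these compounds, it also remains open whether the same ring change would give a similar step with the five-membered carbon ring on the amide, and whether a phenyl ring or a pyridine ring on the same aromatic carbon would move the number further.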